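A few compounds are considered here, and "the series" means these few. Any claim that something is new, unique, unknown or untested is made for them only; others in the source may bear on it.

Working notes on a small set built on a shared core. For the measured compounds named here, compound 1 `OC[C@H]1OC(n2cnc3c(Nc4ccccc4)nccc32)[C@H](O)[C@@H]1O` carries the anilino group; in a functional assay on EL4 cells (Mus musculus) for inhibition, tested at 100 uM (on this read-out lower numbers stand for less inhibition and higher numbers for more inhibition at the one concentration tested (going by the name of the read-out)), compound 1 gives 10%, the only plain number in the set. Compound 2 `[O-][n+]1ccc2c(c1)ncn2C1O[C@H](CO)[C@@H](O)[C@H]1O` returns < 5% in this assay, a limit of the assay. Compound 3 `OC[C@H]1O[C@@H](n2cnc3cnccc32)[C@H](O)[C@@H]1O` returns < 5%; < 5% (2 entries) in this assay in two entries, each a limit of the assay. The floor of the set is described by the limit of < 5% in this assay, at which 1 of the 3 values shown sits. Going by the values given here, no two measured compounds differ in only one place, so no measured step exists here.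

Compound 4 `CCNc1nccc2c1ncn2C1O[C@H](CO)[C@@H](O)[C@H]1O` differs from compound 1 by ethyl in place of phenyl on a nitrogen on an aromatic ring. Since compound 1 gives 10% in this assay, a low inhibition, any step from it is expected to stay within the scatter. The step from compound 1 to compound 4 is expected as a number 4 percentage points lower from compound 1 to compound 4 (within the scatter). Compound 4 is estimated at 6%, between 0% and 16%, with a fair chance that only a limit is reported.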

Compound 4, a percentage reported as inhibition, at one concentration (the size of the read-out at that concentration, not a potency): 8%
Compound 4: the middle estimate sits 2 percentage points below what was measured; the measured number falls inside the stated range.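

For the compounds shown here, this is the first measured step. In this assay, the change of anilino to ethylamino, on a nitrogen on an aromatic ring, gives a number 2 percentage points lower from compound 1 to compound 4 (within the scatter), so at this position phenyl and ethyl cannot be told apart, and the six-membered aromatic ring of the anilino group is not needed for the low inhibition of compound 1. The step is read against a set with little room above its floor: the limit of < 5% in this assay, at which 1 of the 4 values shown sits.

Going by these compounds, what a benzyl group, a longer alkyl chain or a carboxylic acid on the end of such a chain would do on this nitrogen stays open. On these data alone, whether any group at this position can move the read-out beyond the scatter also remains open.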